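The compounds below may be only part of what the source reports. "The series", "measured", "known", "first", "only" and "open" are said of these compounds alone.

Of the compounds shown here, three of a shared core have been measured, and a fourth is waiting. Compound 1 `C=C(C)CCC[C@]1(C)C2=CCC[C@](C)(C[C@@H](O)c3ccoc3)[C@H]2CC[C@H]1C` and compound 2 `C=C(C)CCC[C@]1(C)C2=CCC[C@](C)(C[C@H](O)c3ccoc3)[C@H]2CC[C@H]1C` have the same atoms and bonds and differ only in configuration as drawn. In a functional assay on HT-29 cells (Homo sapiens) for antiproliferative activity, read by XTT assay, with a stated time of 72 h (a higher number here means a weaker inhibitor, a lower number a stronger inhibitor), compound 1 gives 63100 nM, and in the same assay compound 2 gives 63100 nM, so no change at the digits printed from compound 1 to compound 2 (within the scatter). Compound 3 `C=C(C)CCC[C@]1(C)C2=CCC[C@](C)(C[C@H](O)C3=CC(=O)OC3O)[C@H]2CC[C@H]1C` carries a five-membered non-aromatic ring in place of the five-membered aromatic ring, and in this assay compound 3 gives 3000 nM, the lowest of the three numbers: a 21-fold lower number from compound 1 to compound 3 (1.32 log units; beyond the scatter) and a 21-fold lower number from compound 2 to compound 3 (1.32 log units; beyond the scatter).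

Compound 4 `C=C(C)CCC[C@]1(C)C2=CCC[C@](C)(C[C@H](OC(C)=O)C3=CC(=O)OC3O)[C@H]2CC[C@H]1C` keeps that non-aromatic ring and differs from compound 3 in one place: acetyl in place of hydrogen on an oxygen on a saturated carbon. Cut one bond further out, this reads hydroxy to acetoxy. For the measured compounds named here, no measured step bears directly on this change: the two large steps measured concern the ring swap, and the single small step concerns configuration alone. For the step from compound 3 to compound 4 a change within the scatter, or at most a modest one in either direction, is therefore expected, no change at the digits printed from compound 3 to compound 4 (within the scatter). In this assay compound 4 is estimated at 3000 nM, with a likely range from 1000 nM to 10000 nM.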

Compound 4, half-maximal inhibitory concentration: 4200 nM
Compound 4: middle estimate off by 1.4-fold (0.15 log units), on the low side, within the range that was stated.
By their numbers in this assay, from the lowest: compounds 3 and 4 (each within the scatter of the next); then compounds 1 and 2 (each within the scatter of the next).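

Acetyl in place of hydrogen on an oxygen on a saturated carbon, the change from hydroxy to acetoxy, gives in this assay a 1.4-fold higher number from compound 3 to compound 4 (0.15 log units; within the scatter), so this step stays within the scatter. The earlier compounds shown here all carry hydroxy at this place, so they could show nothing about replacing it; here the hydrogen on that oxygen gives way to a larger group with a carbonyl, and the number stays within the scatter of the value for the hydroxy compound. No information given here bears on why the two numbers lie so close, so this remains an observation about this one pair in this one cell assay.

A single acyl group says little about the range of groups this oxygen can carry: a methyl ether, a benzoyl ester or a longer chain on the same oxygen would show whether the result extends beyond acetyl. Going by these compounds, the acetoxy group also appears here only with the five-membered non-aromatic ring and in one drawn configuration, so its effect with the five-membered aromatic ring, or with the opposite configuration at that carbon, remains open.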